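The source may hold more compounds than are shown below. What is called first, only, known or untested is meant among the compounds shown, and "the series" means these compounds.

Compound 1 `CCC[C@@H](OC(C)=O)C1=C(Br)[C@@](CI)(OC)OC1=O` carries the shared core of this small set. Going by the values given here, in a functional assay on KB cells (Homo sapiens) for cytotoxicity (on this read-out lower numbers stand for an effect already at smaller amounts and higher numbers for an effect only at larger amounts of compound), compound 1 gives 4.1 ug/mL, which is the only number measured here. Compound 2 `CCCCC1=C(Br)/C(=C/Br)OC1=O` stands apart: in this assay compound 2 gives > 20 ug/mL, and this is a limit of the assay rather than a number. Among the compounds with values here, the set therefore holds no measured step between two numbers, only the value of compound 1 and (the limit of > 20 ug/mL in this assay, at which 1 of the 2 values shown sits). Compound 3 `CCC[C@@H](OC(C)=O)C1=C(Br)[C@](OC)(C(Br)Br)OC1=O` has not yet been tested in this assay. It differs from compound 1 in a single place: dibromomethyl in place of iodomethyl on a saturated ring carbon. Within the data shown here, with no measured step to lean on, the step of a 1.2-fold higher number from compound 1 to compound 3 (0.09 log units; within the scatter) is expected to stay within the usual scatter, in neither direction beyond it. Compound 3 is accordingly estimated at 5 ug/mL in this assay, with a range from 2 ug/mL to 12 ug/mL.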

Compound 3, concentration for half-maximal effect: 5.3 ug/mL
Beside the measured number, compound 3's estimate is 1.1-fold (0.03 log units) below it; the range from low to high includes it.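

Working notes on the series: in this assay, dibromomethyl in place of iodomethyl on this saturated ring carbon, next to the ring oxygen, gives a 1.3-fold higher number from compound 1 to compound 3 (0.11 log units; within the scatter). Going by these compounds alone, this is the first step that can be read, and it shows that this position can carry either of these two halogenated methyl groups with no difference beyond the usual scatter of the read-out. No measurement at hand bears on why the two groups read alike.

Going by these compounds, whether the position also accepts a group without halogen, such as a plain methyl, an aminomethyl or a carboxylic acid, remains open. Compound 2 gives > 20 ug/mL, which is a limit of the assay and not a number, and it differs from compound 1 in more than one place, so it adds no readable step.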